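Lengthening the Hydroxycarbamoyl Chain on Two Related Cores

This account rests on a few compounds, and the source may have more. Where it says the series, first, only, none or still open, it means among the compounds named here.

Compound 1, `C#CCN(C)Cc1cccc(NC(=O)CCC(=O)NO)c1`: > 10000 nM
Compound 2, `C#CCN(C)Cc1cccc(NC(=O)CCCC(=O)NO)c1`: > 10000 nM
Compound 3, `C#CCN(C)Cc1ccc(NC(=O)CCC(=O)NO)cc1`: > 10000 nM

In a functional assay on PC-3 cells (Homo sapiens) for inhibition, read by MTT assay, with a stated time of 48 h (on this read-out higher numbers stand for weaker inhibition of growth and lower numbers for stronger inhibition of growth), compound 1 gives > 10000 nM, which is a limit of the assay and not a number. Compound 2 likewise gives > 10000 nM in this assay, again a limit. Compound 3 gives > 10000 nM in this assay, also a limit. Compound 1 and compound 2 differ by (hydroxycarbamoyl)methyl in place of hydroxycarbamoyl on a saturated chain carbon, two bonds along the chain from a carbonyl carbon, and the step that the two limits leave unreadable from compound 1 to compound 2 cannot be sized, since both ends sit at the limit. Compound 1 and compound 3 share the same atoms joined differently; the difference between the two cores is not broken down here. Compound 4, `C#CCN(C)Cc1ccc(NC(=O)CCCC(=O)NO)cc1`, carries the same change relative to compound 3, namely ((hydroxycarbamoyl)methyl in place of hydroxycarbamoyl on a saturated chain carbon, two bonds along the chain from a carbonyl carbon), at a place worded identically for both pairs, so it is the same change. All measured values sit at the limit of > 10000 nM in this assay, at which 3 of the 3 values shown sit. Because of the limit of > 10000 nM in this assay, at which 3 of the 3 values shown sit, compound 4 is expected to stay at or beyond that limit, so the expected step that the limit leaves unreadable from compound 3 to compound 4 is essentially flat. Compound 4 is therefore estimated at 20000 nM, within 6000 nM to 60000 nM.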

Compound 4, concentration for 50% growth inhibition: > 10000 nM
Compound 4: no number, only a limit; the forecaster's own chance of this, stated with the estimate: 85%; the middle value does not contradict the limit.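

No step can be read from compound 3 to compound 4, as with the earlier pair of compound 1 and compound 2; both values are limits of the assay and not numbers. The compounds shown leave open how strongly any of them inhibits growth in this assay and whether the longer chain changes that at all: the limit of > 10000 nM in this assay, at which 4 of the 4 values shown sit.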